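Working notes: chloro in place of methyl

A few compounds are considered here, and "the series" means these few. Any claim that something is new, unique, unknown or untested is made for them only; others in the source may bear on it.

Measured in a functional assay on CCRF-CEM cells (Homo sapiens) for antiproliferative activity, read by cell counting, with a stated time of 2 days; a higher number here means a weaker inhibitor, a lower number a stronger inhibitor:
- compound 1 `COc1cc(C(=O)c2sc(Nc3ccccc3)nc2N)cc(OC)c1OC`: 9.4 nM
- compound 2 `COc1cc(C(=O)c2sc(Nc3ccc(F)cc3)nc2N)cc(OC)c1OC`: 400 nM
- compound 3 `COc1cc(C(=O)c2sc(Nc3ccc(C)cc3)nc2N)cc(OC)c1OC`: 41 nM

Compound 3 stands second highest of the three numbers, above compound 1 and below compound 2. Compound 4 `COc1cc(C(=O)c2sc(Nc3ccc(Cl)cc3)nc2N)cc(OC)c1OC` has chloro in place of methyl on an aromatic carbon, para to a large group: chloro in place of methyl on an aromatic carbon. Going by the values given here, no chloro compound has been measured, so the evidence is indirect. Both substituents raised the number over hydrogen: a 43-fold higher number from compound 1 to compound 2 (1.63 log units; beyond the scatter) is large and a 4.4-fold higher number from compound 1 to compound 3 (0.64 log units; beyond the scatter) is modest. Exchanging them gave a 9.8-fold lower number from compound 2 to compound 3 (0.99 log units; beyond the scatter), also modest. A modest rise in this assay is expected, though the direction is uncertain. The expected step is a 2.9-fold higher number from compound 3 to compound 4 (0.47 log units; beyond the scatter). Compound 4 is estimated at 120 nM, with an expected range of 30 nM to 500 nM.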

Compound 4, half-maximal inhibitory concentration: 190 nM
Beside the measured number, compound 4's estimate is 1.6-fold (0.20 log units) below it; measured number inside the range.
By their numbers in this assay, from the lowest: compound 1; then compound 3; then compound 4; then compound 2.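

In this assay, chloro in place of hydrogen gives a 20-fold higher number from compound 1 to compound 4 (1.31 log units; beyond the scatter), so all three substituents shown at this position, para to a large group, raise the number over hydrogen. Chloro in place of methyl gives a 4.6-fold higher number from compound 3 to compound 4 (0.67 log units; beyond the scatter), and chloro in place of fluoro gives a 2.1-fold lower number from compound 2 to compound 4 (0.32 log units; beyond the scatter), which places chloro between the other two substituents in these four compounds. No measurement shown accounts for this order.

On these data alone, whether a methoxy group or an amine here would also raise the number over hydrogen remains open. So does whether any substituent at this position can match hydrogen.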